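This account rests on a few compounds, and the source may have more. Where it says the series, first, only, none or still open, it means among the compounds named here.

In a functional assay on NUGC-3 cells (Homo sapiens) for antiproliferative activity, read by XTT assay (a higher number here means a weaker inhibitor, a lower number a stronger inhibitor), compound 1 `CC(C)COc1cccc2occ(Cc3coc4ccccc4c3=O)c(=O)c12` gives > 10000 nM as a limit, not a number. Compound 2 `CC(C)CCOc1cccc2occ(Cc3coc4ccccc4c3=O)c(=O)c12` likewise gives > 10000 nM as a limit. Compound 2 thus stands at the limit of > 10000 nM in this assay, at which 2 of the 2 values shown sit, with no number of its own. Within the data shown here, the one measured step is a step that the two limits leave unreadable from compound 1 to compound 2 and offers no size to carry forward. Compound 3 `O=c1c(Cc2coc3cccc(O)c3c2=O)coc2ccccc12` differs from compound 2 by hydrogen in place of isopentyl on an oxygen on an aromatic ring as the change of isopentyloxy to hydroxy. With no measured size to draw on, only a tentative shift toward stronger inhibition is expected. The estimated step is an at least 1.1-fold lower number from compound 2 to compound 3 (0.04 log units; that floor lies within the scatter). For compound 3 the expected value is 9000 nM within an estimated range of 2500 nM to 30000 nM in this series.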

Compound 3, half-maximal inhibitory concentration: 3270 nM
Beside the measured number, compound 3's estimate is 2.8-fold (0.44 log units) above it; the range from low to high includes it.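

In this assay, among these compounds, the oxygen on an aromatic ring is the first place where a change gives a readable step: hydrogen in place of isopentyl gives an at least 3.0-fold lower number from compound 2 to compound 3 (0.48 log units; beyond the scatter), and hydrogen in place of isobutyl gives an at least 3.0-fold lower number from compound 1 to compound 3 (0.48 log units; beyond the scatter). Hydroxy therefore separates compound 3 from both ethers, while the step between the two ethers cannot be read. Both readable steps are floors, not full sizes: the limit of > 10000 nM in this assay, at which 2 of the 3 values shown sit.

Open, on these data alone, is whether methoxy, a shorter chain on the same oxygen, stays at the limit or approaches compound 3. Also open, as far as these compounds go, is how an amine in place of hydroxy would read.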